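This account rests on a few compounds, and the source may have more. Where it says the series, first, only, none or still open, it means among the compounds named here.

Of the compounds shown here, three built on one shared core have been measured in a functional assay on DU-145 cells (Homo sapiens) for cytotoxicity, read by MTT assay; a lower number here means a stronger inhibitor, a higher number a weaker inhibitor. Compound 1 `CC(=O)OCCO[C@H](CC=C(C)C)C1=CC(=O)c2c(O)ccc(O)c2C1=O` gives 15500 nM in this assay, the lowest of the three numbers, although compound 3 `CC(C)=CC[C@@H](OC(=O)CC(O)c1ccccc1)C1=CC(=O)c2c(O)ccc(O)c2C1=O`, which gives 17000 nM, sits within the usual scatter of it; only compound 2 `CCCC(CC(=O)O[C@H](CC=C(C)C)C1=CC(=O)c2c(O)ccc(O)c2C1=O)OC(C)=O`, which gives 55700 nM, lies clearly beyond it. Compounds 2 and 3 carry esters that differ only in the acyl part, and the step of a 3.3-fold lower number from compound 2 to compound 3 (0.52 log units; beyond the scatter) shows that swapping this part shifts the number modestly.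

Compound 4 `CC(C)=CC[C@@H](OC(=O)C1CCCCO1)C1=CC(=O)c2c(O)ccc(O)c2C1=O` has not yet been measured. It differs from compound 1 by (oxan-2-yl)carbonyl in place of 2-acetoxyethyl on an oxygen on a saturated carbon. Here a side group joined through an oxygen becomes an ester whose acyl part carries a ring, so compound 4 joins compounds 2 and 3 as an ester of the same core. Within the data shown here, no measured step follows this exact change; the nearest guide is the step between the two esters, which was modest, and the two esters themselves give numbers no lower than compound 1. The step of a 1.4-fold higher number from compound 1 to compound 4 (0.15 log units; within the scatter) is therefore expected to be small, if anything toward a higher number. Compound 4 is estimated at 22000 nM, within a range from 8000 nM to 60000 nM.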

Compound 4, half-maximal inhibitory concentration: 24700 nM
The estimate for compound 4 lay 1.1-fold (0.05 log units) below the measured number; the measured number falls inside the stated range.
By their numbers in this assay, from the lowest: compounds 1, 3 and 4 (each within the scatter of the next); then compound 2.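

In this assay, replacing the 2-acetoxyethyl group on this oxygen with (oxan-2-yl)carbonyl turns the open side chain into an ester with a ring in it, yet the step stays small: a 1.6-fold higher number from compound 1 to compound 4 (0.20 log units; within the scatter). Among the esters, the ring-bearing acyl part reads much like the one with the hydroxy and phenyl groups, a 1.5-fold higher number from compound 3 to compound 4 (0.16 log units; within the scatter), while a 2.3-fold lower number from compound 2 to compound 4 (0.35 log units; beyond the scatter) sets compound 2, with its 2-acetoxypentyl group, apart from compound 4, so that only compound 2 stands clearly away from the other three compounds. No supporting measurement is available to explain why these side groups give these numbers.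

Still open, from the compounds shown here alone, is whether the ring oxygen matters at all, since a plain cyclohexyl group in place of oxan-2-yl would be needed to separate the effect of the ring from that of its oxygen. Going by these compounds, it is also open whether an ester carrying an amine or a carboxylic acid in its acyl part would stay close to compounds 1, 3 and 4 or move toward compound 2.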